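Tolerance of a Short Amide Side Chain Variant

The source may report more compounds than this note shows. Statements on the series, on what has been measured and on what is new or still open speak of the compounds shown alone.

Three compounds sharing one core were tested in an ADME assay on CEM-SS cells (Homo sapiens) for cytotoxicity, read by XTT assay, with a stated time of 6 days; a higher number here means that more compound is tolerated, a lower number that less compound is tolerated. Compound 1 `CCCC(=O)OCSc1ccccc1C(=O)NCCC(N)=O` carries a carbamoyl-ended chain. In this assay compound 1 gives > 100 uM, which is a limit of the assay rather than a number, and the limit of > 100 uM in this assay, at which 1 of the 3 values shown sits, marks where it sits. Compound 2 `CCCC(=O)OCSc1ccccc1C(=O)NCCCCNC(C)=O` gives 17.4 uM and compound 3 `CCCC(=O)OCSc1ccccc1C(=O)NCCCCCNC(C)=O` gives 9.2 uM. The step of an at least 5.7-fold lower number from compound 1 to compound 2 (0.75 log units; beyond the scatter) and the step of an at least 10-fold lower number from compound 1 to compound 3 (1.03 log units; beyond the scatter) both move toward less tolerated compound, while a 1.9-fold lower number from compound 2 to compound 3 (0.28 log units; within the scatter) does not separate compound 2 from compound 3.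

Compound 4 `CCCC(=O)OCSc1ccccc1C(=O)NCC(=O)N(C)C` has not yet been measured. It differs from compound 1 as follows: dimethylcarbamoyl in place of carbamoylmethyl on a saturated chain carbon bound to an amide-type nitrogen. Unlike the two measured steps, this change does not lengthen the chain; it removes a chain carbon and methylates the terminal amide. The measured steps therefore bear on it only loosely, and a smaller shift than either is expected, if any beyond the scatter.

For compound 4 the expected value in this assay is 80 uM, within 30 uM to 150 uM. The expected step is an at least 1.2-fold lower number from compound 1 to compound 4 (0.09 log units; that floor lies within the scatter), and a reported limit rather than a number remains quite possible.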

Compound 4, half-maximal toxic concentration: 38.3 uM
The estimate for compound 4 lay 2.1-fold (0.32 log units) above the measured number; the measured number falls inside the stated range.
By their numbers in this assay, from the lowest: compounds 3 and 2 (each within the scatter of the next); then compound 4. At a limit, above all of these: compound 1.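

In this assay, a short side chain does not by itself guarantee the highest tolerance: dimethylcarbamoyl in place of carbamoylmethyl gives an at least 2.6-fold lower number from compound 1 to compound 4 (0.41 log units; beyond the scatter), a shift beyond the scatter from a change that does not lengthen the chain. Compound 4 also stands clear of the longer acetamido-ended chains, with a 4.2-fold higher number from compound 3 to compound 4 (0.62 log units; beyond the scatter) and a 2.2-fold higher number from compound 2 to compound 4 (0.34 log units; beyond the scatter), so the short chain keeps an advantage over both even with its terminal amide methylated. Compound 1 remains a limit and not a number, so its step gives only a floor: the limit of > 100 uM in this assay, at which 1 of the 4 values shown sits.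

Removing a chain carbon and methylating the terminal amide happen together in compound 4, and the two contributions cannot be told apart here. On these data alone, whether a short chain ending in an amine or a carboxylic acid would be tolerated as well also remains open.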